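The source may report more compounds than this note shows. Statements on the series, on what has been measured and on what is new or still open speak of the compounds shown alone.

Measured so far:
- compound 1 `COc1cccc(/C=C2\CCC/C(=C\c3cccc(Cl)c3)C2=O)c1OC` — > 20000 nM
- compound 2 `COc1cccc(/C=C2\CCC/C(=C\c3cccc(OC)c3OC)C2=O)c1` — 16400 nM
- compound 3 `COc1cccc(/C=C2\CCC/C(=C\c3ccc(O)c(Cl)c3)C2=O)c1OC` — > 20000 nM

In a functional assay on A549 cells (Homo sapiens) for cytotoxicity, read by MTT assay, with a stated time of 72 h (a lower number here means a stronger inhibitor, a higher number a weaker inhibitor), compound 1 gives > 20000 nM, which is a limit of the assay and not a number. In this assay compound 3 likewise gives > 20000 nM, again a limit and not a number. Only compound 2 gives a number, 16400 nM in this assay.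

The change methoxy in place of chloro on an aromatic carbon carries the step of an at least 1.2-fold lower number from compound 1 to compound 2 (0.08 log units; that floor lies within the scatter). The cores of compound 1 and compound 3 differ by hydroxy in place of hydrogen on an aromatic carbon, and the step that the two limits leave unreadable from compound 1 to compound 3 cannot be read because of the limit of > 20000 nM in this assay, at which 2 of the 3 values shown sit. Between compound 2 and compound 3 the step is an at least 1.2-fold higher number from compound 2 to compound 3 (0.08 log units; that floor lies within the scatter).

Compound 4 `COc1cc(/C=C2\CCC/C(=C\c3cccc(OC)c3OC)C2=O)ccc1O` is not yet measured. It differs from compound 3 by methoxy in place of chloro on an aromatic carbon, the same kind of change as from compound 1 to compound 2, but here the place is ortho to a hydroxy group, which is absent in compound 1 and compound 2. Among the compounds with values here, the earlier step of an at least 1.2-fold lower number from compound 1 to compound 2 (0.08 log units; that floor lies within the scatter) is the only guide, and it rests on a limit. The expected step of an at least 1.1-fold lower number from compound 3 to compound 4 (0.04 log units; that floor lies within the scatter) in this assay is estimated to be of that order, small and uncertain, since compound 3 sits at > 20000 nM, a limit. Compound 4 is expected to give about 18000 nM in this assay, estimated between 8000 nM and 40000 nM, with a fair chance that only a limit is reported.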

Compound 4, half-maximal inhibitory concentration: > 20000 nM
Compound 4: no number, only a limit; the forecaster's own chance of this, stated with the estimate: 55%; at least 1.1-fold (0.04 log units) between middle value and limit.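

In this assay compound 4 gives > 20000 nM, a limit of the assay and not a number. The change of methoxy in place of chloro on an aromatic carbon, carried from the pair compound 1 and compound 2 to the hydroxy-bearing pair compound 3 and compound 4, gives nothing to compare, and the steps from compound 3 to compound 4 and from compound 1 to compound 4 cannot be read because both ends of each stand at a limit: the limit of > 20000 nM in this assay, at which 3 of the 4 values shown sit. The one step that can be read, hydroxy in place of hydrogen on an aromatic carbon, is an at least 1.2-fold higher number from compound 2 to compound 4 (0.08 log units; that floor lies within the scatter); the compounds shown therefore neither confirm that the methoxy change carries over from one core to the other nor show that it fails to.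

All the compounds shown carry only methoxy, chloro and hydroxy on their aromatic rings, so the effect of an amine, a carboxylic acid or a longer chain such as ethoxy or butoxy on these rings remains open. Also open, on these data alone, is whether any change to the shared core would give more compounds with a number in this assay, where compound 2 alone has one so far.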